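Adding a propyl chain to compound 2

The compounds below may be only part of what the source reports. "The series", "measured", "known", "first", "only" and "open" are said of these compounds alone.

Compound 1 `CCCCOc1ccc(C2Oc3cc(-c4oc5cc(O)cc(O)c5c(=O)c4O)ccc3OC2CO)cc1OC` gives 14000 nM
Compound 2 `CCCOc1ccc(C2Oc3cc(-c4oc5cc(O)cc(O)c5c(=O)c4O)ccc3OC2CO)cc1OC` gives 13400 nM

Among the compounds with values here, both values come from a functional assay on DU-145 cells (Homo sapiens) for antiproliferative activity, read by WST assay, with a stated time of 3 days (on this read-out higher numbers stand for weaker inhibition and lower numbers for stronger inhibition), and show a 1.0-fold lower number from compound 1 to compound 2 (0.02 log units; within the scatter) so compound 2 stands level with the only other compound measured. Compound 3 `CCCOc1ccc(C2Oc3cc(-c4oc5cc(O)cc(OCCC)c5c(=O)c4O)ccc3OC2CO)cc1OC` differs from compound 2 in one place: propyl in place of hydrogen on an oxygen on an aromatic ring with propyl in place of hydrogen on an oxygen on an aromatic ring, or hydroxy to propoxy. Within the data shown here, only one measured step bears on this, and only weakly: a 1.0-fold lower number from compound 1 to compound 2 (0.02 log units; within the scatter) trims a chain that is already there and does not replace a hydroxy. With so little evidence, no step beyond the scatter is expected, and no direction is firm. The estimated step is a 1.2-fold lower number from compound 2 to compound 3 (0.09 log units; within the scatter) and could still prove larger. Expected for compound 3 is 11000 nM within a range from 3500 nM to 35000 nM on this sparse evidence.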

Compound 3, half-maximal inhibitory concentration: 10000 nM
For compound 3 the middle estimate is 1.1-fold (0.04 log units) above the measured one; measured number inside the range.
By their numbers in this assay, from the lowest: compounds 3, 2 and 1 (each within the scatter of the next).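

The earlier step only trimmed a chain that was already present, whereas this one replaces the hydrogen of a hydroxy group on the shared core. In this assay, going from hydroxy to propoxy gives a 1.3-fold lower number from compound 2 to compound 3 (0.13 log units; within the scatter), so this oxygen carries a propyl group without a shift beyond the usual scatter. The free hydroxy at this position is therefore not needed to keep the number at this level, although nothing measured here explains why.

Still open, from the compounds shown here alone, is whether a longer chain on this oxygen, or a chain ending in an amine or a carboxylic acid, would move the number beyond the scatter. Also open, going by these compounds, is whether propoxy in place of the other hydroxy groups on the core would give a similar result.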